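The source may hold more compounds than are shown below. What is called first, only, known or untested is meant among the compounds shown, and "the series" means these compounds.

Measured compounds:
- Compound 1 `COc1ccccc1Oc1c(N)nc(-c2cccc(C)c2)nc1Cl`: 65300 nM
- Compound 2 `COc1ccccc1Oc1c(N)nc(-c2ccc(I)cc2)nc1Cl`: 480 nM
- Compound 3 `COc1ccccc1Oc1c(N)nc(-c2cccc(C)c2)nc1OCCO`: 1380 nM

In a functional assay on A-375 cells (Homo sapiens) for cytotoxicity, read by CCK-8 assay, with a stated time of 24 h (on this read-out higher numbers stand for weaker inhibition and lower numbers for stronger inhibition), compound 1 gives 65300 nM, the highest of the three numbers. Compound 3 stands second highest in this assay, well below compound 1 and above compound 2, whose value of 480 nM lies beyond the scatter from that of compound 3.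

Compound 4 `COc1ccccc1Oc1c(N)nc(-c2cccc(I)c2)nc1OCCO` is not yet measured. It differs from compound 3 in one place: iodo in place of methyl on an aromatic carbon, on an aromatic carbon of a six-membered aromatic ring of carbon only, meta to a large group.

Among the compounds with values here, one measured step bears on this, though not exactly: a 140-fold lower number from compound 1 to compound 2 (2.13 log units; beyond the scatter), where 4-iodophenyl replaced 3-methylphenyl. Within the data shown here, that step is large but the iodo there sits at a different position from the one in compound 4, so the same size cannot be assumed. The other step, a 47-fold lower number from compound 1 to compound 3 (1.68 log units; beyond the scatter), concerns the other side of the core and is already built into compound 3.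

Among the measured compounds shown here, a lower number is therefore expected for compound 4, by a step of roughly a 6.9-fold lower number from compound 3 to compound 4 (0.84 log units; beyond the scatter), smaller than the only comparable step. Compound 4 is estimated at 200 nM, with a range from 40 nM to 1000 nM.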

Compound 4, half-maximal inhibitory concentration: 1230 nM
Compound 4: middle estimate off by 6.2-fold (0.79 log units), on the low side, outside the stated range (above it).
By their numbers in this assay, from the lowest: compound 2; then compounds 4 and 3 (each within the scatter of the next); then compound 1.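

On this assay, iodo in place of methyl on this aromatic carbon gives a 1.1-fold lower number from compound 3 to compound 4 (0.05 log units; within the scatter), so with the 2-hydroxyethoxy group on the core, 3-iodophenyl and 3-methylphenyl cannot be told apart. The earlier 140-fold lower number from compound 1 to compound 2 (2.13 log units; beyond the scatter) therefore cannot be read as a general gain from having an iodo on this ring: that step moved to 4-iodophenyl with chloro on the core, whereas 3-iodophenyl with 2-hydroxyethoxy shows no change beyond the scatter. Nothing available explains why methyl and iodo read alike here.

The compounds shown leave open whether 3-iodophenyl would behave the same way with chloro on the core, and whether 4-iodophenyl would keep its low number with 2-hydroxyethoxy there. They also leave open what an amine or a carboxylic acid would do on this aromatic carbon.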